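Cytotoxicity notes on a para-substituted aryl series

This account rests on a few compounds, and the source may have more. Where it says the series, first, only, none or still open, it means among the compounds named here.

Measured so far:
compound 1 `N#CSCc1nc(-c2ccc(C(=O)O)cc2)no1` — 383000 nM
compound 2 `COC(=O)c1ccc(-c2noc(CSC#N)n2)cc1` — 43700 nM
compound 3 `Nc1nnc(-c2ccc(C(=O)O)cc2)s1` — > 400000 nM

In an ADME assay on MT2 cells (Homo sapiens) for cytotoxicity, read by XTT assay, with a stated time of 4 days (on this read-out lower numbers stand for higher toxicity in this test and higher numbers for lower toxicity in this test), compound 1 gives the highest of the two numbers shown. Compound 2 sits an 8.8-fold lower number from compound 1 to compound 2 (0.94 log units; beyond the scatter) away. For compound 3 the result in this assay is a limit, not a number: the limit of > 400000 nM in this assay, at which 1 of the 3 values shown sits.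

Compound 4 `O=C(O)c1ccc(-c2noc(CBr)n2)cc1` differs from compound 1 by bromo in place of cyanosulfanyl on a saturated chain carbon bound to an aromatic carbon. No measured step in this assay touches that position; the only step shown, from compound 1 to compound 2, changes the acid end and is therefore uninformative here. With nothing to rest on, compound 4 is expected to move by a 2.6-fold lower number from compound 1 to compound 4 (0.41 log units; beyond the scatter), a modest shift towards a lower number. Compound 4 is estimated at 150000 nM, within 40000 nM to 400000 nM.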

Compound 4, half-maximal cytotoxic concentration: 81900 nM
Compound 4: the middle estimate sits 1.8-fold (0.26 log units) above what was measured; low and high end bracket the measured number.
By their numbers in this assay, from the lowest: compounds 2 and 4 (each within the scatter of the next); then compound 1. At a limit, above all of these: compound 3.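

Bromo in place of cyanosulfanyl gives a 4.7-fold lower number from compound 1 to compound 4 (0.67 log units; beyond the scatter) in this assay, so the number responds to a change on the saturated chain carbon bound to an aromatic carbon, a place the earlier step did not touch. Cyanosulfanyl is therefore not the only group at this place that gives a measurable number in this read-out. Nothing shown accounts for the size of this step.

From the compounds shown here alone, whether an amine, a hydroxyl or a longer chain at this place would shift the number likewise stays open. So does whether the same change holds on compound 2.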